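Thiophene-bearing nucleosides: from methylamino to methylsulfanyl

The compounds below may be only part of what the source reports. "The series", "measured", "known", "first", "only" and "open" are said of these compounds alone.

Three nucleosides share one core. Compound 1 `CNc1ncnc2c1c(I)cn2[C@@H]1O[C@H](CO)[C@@H](O)[C@H]1O` carries an iodo group; compound 2 `CNc1ncnc2c1c(-c1cccs1)cn2[C@@H]1O[C@H](CO)[C@@H](O)[C@H]1O` carries a thiophen-2-yl group; compound 3 `CNc1ncnc2c1c(-c1ccsc1)cn2[C@@H]1O[C@H](CO)[C@@H](O)[C@H]1O` carries a thiophen-3-yl group. In a functional assay on A549 cells (Homo sapiens), read by MTT assay, with a stated time of 72 h (on this read-out higher numbers stand for weaker inhibition and lower numbers for stronger inhibition), compound 1 gives only a limit, > 100000 nM. In this assay compound 2 likewise gives only a limit, > 20000 nM. Compound 3 also gives only a limit in this assay, > 20000 nM. Because of the limit of > 100000 nM in this assay, at which 1 of the 3 values shown sits, and (the limit of > 20000 nM in this assay, at which 2 of the 3 values shown sit), none of the steps a step that the two limits leave unreadable from compound 1 to compound 2, a step that the two limits leave unreadable from compound 1 to compound 3 and a step that the two limits leave unreadable from compound 2 to compound 3 can be sized, and compound 3 stands at the same limit as compound 2, with no readable ordering among the three.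

Compound 4 `CSc1ncnc2c1c(-c1ccsc1)cn2[C@@H]1O[C@H](CO)[C@@H](O)[C@H]1O` differs from compound 3 by the change (methylsulfanyl in place of methylamino on an aromatic carbon). Going by the values given here, no measured step concerns this group, so no direction can be derived from the data; the weight of three limits suggests that this assay will again report no number. Compound 4 is therefore expected to show a step that the limit leaves unreadable from compound 3 to compound 4, and its estimated value is 50000 nM, within 10000 nM to 200000 nM.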

Compound 4, half-maximal inhibitory concentration: > 20000 nM
Compound 4 ended at the assay's limit (the forecaster's own chance of this, stated with the estimate: 85%); the middle value lies beyond the limit too.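

Compound 3 and compound 4 both stand at limits in this assay, not at numbers, so the step between them cannot be read. The compounds shown leave open how strongly any of them acts in this assay, and whether exchanging methylamino for methylsulfanyl changes that at all.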